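This account rests on a few compounds, and the source may have more. Where it says the series, first, only, none or still open, it means among the compounds named here.

In a functional assay on HT-29 cells (Homo sapiens) for inhibition, read by MTT assay, with a stated time of 72 h (on this read-out lower numbers stand for stronger inhibition and higher numbers for weaker inhibition), compound 1 `O=C1N/C(=N/c2nc3cc(-c4ccc(Cl)cc4)sc3s2)S/C1=C/c1ccc2ccccc2c1` reaches only a limit, > 50000 nM. Going by the values given here, compound 2 `Cc1ccc(/C=C2/S/C(=N\c3nc4cc(-c5ccc(Cl)cc5)sc4s3)NC2=O)cc1` gives 45500 nM, the only actual number so far. Compound 3 `O=C1N/C(=N/c2nc3cc(-c4ccc(Cl)cc4)sc3s2)S/C1=C/c1ccc(Cl)cc1` differs from compound 2 by chloro in place of methyl on an aromatic carbon, with chloro in place of methyl on an aromatic carbon, so that 4-methylphenyl becomes 4-chlorophenyl. Among the compounds with values here, one measured step bears on this group, an at least 1.0-fold lower number from compound 1 to compound 2 (0.04 log units; that floor lies within the scatter), where a different aryl group at the same place left the reading within the scatter. From the compounds shown here alone, its true size stays open because of the limit of > 50000 nM in this assay, at which 1 of the 2 values shown sits. Within the data shown here, with that step as the only guide, no change beyond the scatter is expected in this assay, and compound 3 may also end at a limit. The estimated step is a 1.1-fold lower number from compound 2 to compound 3 (0.06 log units; within the scatter). Compound 3 is expected at 40000 nM, with an estimated range of 15000 nM to 80000 nM.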

Compound 3, half-maximal inhibitory concentration: > 50000 nM
Compound 3 ended at the assay's limit (the forecaster's own chance of this, stated with the estimate: 40%); at least 1.2-fold (0.09 log units) between middle value and limit.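

In this assay, chloro in place of methyl on an aromatic carbon, para to a large group, gives an at least 1.0-fold higher number from compound 2 to compound 3 (0.04 log units; that floor lies within the scatter). This is a second exchange at the same aryl group, and again no change beyond the scatter can be shown, though the true size of the step stays open: the limit of > 50000 nM in this assay, at which 2 of the 3 values shown sit. The step from compound 1 to compound 3 cannot be read, and compound 2, at 45500 nM, remains the only actual number in the set.

From the compounds shown here alone, it stays open whether an amine or a carboxylic acid on this aromatic carbon would bring a reading clearly inside the range of the assay. Going by these compounds, it also stays open whether any change on the shared core, away from this aryl group, would move the reading at all.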